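Chain extension on the shared core: compound 1 to compound 3

The compounds below may be only part of what the source reports. "The series", "measured", "known", "first", "only" and "open" are said of these compounds alone.

For the measured compounds named here, compound 1 `CC(C)=CCn1cnc2c(Nc3cccc(Cl)c3)nc(N[C@H]3CC[C@H](N)CC3)nc21` and compound 2 `CCCCCCn1cnc2c(Nc3cc(OC)cc(OC)c3)nc(N[C@H]3CC[C@H](N)CC3)nc21` are the two measured members. Going by the values given here, in a functional assay on HCC827 cells (Homo sapiens) for inhibition, read by fluorescence, with a stated time of 72 h (on this read-out higher numbers stand for weaker inhibition of growth and lower numbers for stronger inhibition of growth), compound 1 gives 13500 nM, and compound 2 gives 9100 nM; the two numbers lie within the usual scatter of each other, so compound 1 stands level with its only neighbour. Compound 3 `CC(C)=CCC/C(C)=C/Cn1cnc2c(Nc3cccc(Cl)c3)nc(N[C@H]3CC[C@H](N)CC3)nc21` carries the change (3-methylbut-2-en-1-yl in place of hydrogen on a saturated chain carbon bound to a double-bonded chain carbon). Among the compounds with values here, no measured pair shows a step of this kind, so the size is open; the expected step from compound 1 to compound 3 is a 1.2-fold lower number from compound 1 to compound 3 (0.09 log units; within the scatter), no larger than the scatter in either direction. For compound 3 the estimated value is 11000 nM, expected between 3500 nM and 35000 nM.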

Compound 3, concentration for 50% growth inhibition: 18200 nM
Compound 3: the middle estimate sits 1.7-fold (0.22 log units) below what was measured; the measured number falls inside the stated range.
By their numbers in this assay, from the lowest: compounds 2, 1 and 3 (each within the scatter of the next).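

At this position, 3-methylbut-2-en-1-yl and the longer 3,7-dimethylocta-2,6-dien-1-yl can now be compared directly on the shared core. In this assay, for the compounds shown here, the change gives a 1.3-fold higher number from compound 1 to compound 3 (0.13 log units; within the scatter) and so leaves the read-out unmoved, which is the first single-change step read. Nothing available here accounts for this result. Still open, from the compounds shown here alone, is whether a chain bearing an amine or a carboxylic acid would move the number beyond the scatter.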